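Chain swap on the carbonyl oxygen of compound 2

The compounds below may be only part of what the source reports. "The series", "measured", "known", "first", "only" and "open" are said of these compounds alone.

For the measured compounds named here, compound 2 `C#CCCOC(=O)c1ccc(C(CC)(CC)c2ccc(OCC(O)C(C)(C)C)c(C)c2)n1CC` stands at the weaker end of the two numbers so far: in an assay on HL-60 cells for agonist activity at vitamin D3 receptor (Homo sapiens), read by microscopy, with a stated time of 96 h (a lower number here means that less compound is needed, a higher number that more compound is needed for the effect), compound 2 gives 1030 nM, whereas compound 1 `CCn1c(C(=O)NCCN(C)C)ccc1C(CC)(CC)c1ccc(OCC(O)C(C)(C)C)c(C)c1` gives 14 nM. Going by the values given here, the only step in hand, a 74-fold higher number from compound 1 to compound 2 (1.87 log units; beyond the scatter), concerns the group on the carbonyl carbon and shows how far the number can move at that position. Compound 3 `CCn1c(C(=O)OCc2ccc(F)cc2)ccc1C(CC)(CC)c1ccc(OCC(O)C(C)(C)C)c(C)c1` keeps the oxygen linkage of compound 2 and alters only the chain beyond it: 4-fluorophenyl in place of propargyl on a saturated chain carbon bound to an oxygen next to a carbonyl group. Among the compounds with values here, no measured step compares two such chains on the oxygen next to the carbonyl, so the large step from compound 1 to compound 2 gives a scale of what is possible rather than a direction. The expected step of a 1.5-fold lower number from compound 2 to compound 3 (0.17 log units; within the scatter) is therefore modest, with no firm direction beyond the scatter. Compound 3 is estimated at 700 nM, with a range from 150 nM to 3500 nM.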

Compound 3, half-maximal effective concentration: > 50000 nM
Compound 3 gave a limit, no number; the forecaster's own chance of this, stated with the estimate: 10%; middle value at least 71-fold (1.85 log units) away from the limit.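

Compound 3 reads only as a limit of the assay, not as a number: the limit of > 50000 nM in this assay, at which 1 of the 3 values shown sits. For the compounds shown here, the chain beyond the oxygen is itself a large lever at this position, which no earlier step could show: 4-fluorophenyl in place of propargyl on a saturated chain carbon bound to an oxygen next to a carbonyl group gives an at least 48-fold higher number from compound 2 to compound 3 (1.68 log units; beyond the scatter). Set against (2-(dimethylamino)ethyl)amino, (4-fluorobenzyl)oxy on the carbonyl carbon gives an at least 3500-fold higher number from compound 1 to compound 3 (3.55 log units; beyond the scatter), so the range at this carbonyl carbon is wider than the single earlier step indicated.

The compounds shown do not separate the effect of the aromatic ring, the fluorine and the chain length; a plain benzyl or a saturated butyl chain on the same oxygen would address this. From the compounds shown here alone, it also remains open whether a 2-(dimethylamino)ethoxy group on the carbonyl carbon would give a number close to that of compound 1.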